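Working notes: from compound 2 to compound 3

The source may report more compounds than this note shows. Statements on the series, on what has been measured and on what is new or still open speak of the compounds shown alone.

Values so far in an ADME assay on Caco-2 cells (Homo sapiens) for permeability, in the apical to basolateral direction, at pH 7.4; on this read-out lower numbers stand for lower permeability and higher numbers for higher permeability
- compound 1 `O=C(N[C@H]1CN(S(=O)(=O)c2ccccc2)C[C@@H]1C(=O)N[C@H]1CCCNC1)c1cc(-c2ccccc2Cl)on1` gives 0.31 10^-6 cm/s
- compound 2 `CN(C(=O)[C@H]1CN(S(=O)(=O)c2ccccc2)C[C@@H]1NC(=O)c1cc(-c2ccccc2Cl)on1)[C@H]1CCCNC1` gives 0.11 10^-6 cm/s

Compound 2 holds the lower of the two numbers. The change to compound 3 `O=CN1CCC[C@H](NC(=O)[C@H]2CN(S(=O)(=O)c3ccccc3)C[C@@H]2NC(=O)c2cc(-c3ccccc3Cl)on2)C1` is a group of 9 heavy atoms (6 carbon, 2 nitrogen, 1 oxygen; one six-membered non-aromatic ring with 1 hetero atom) in place of a group of 8 heavy atoms (6 carbon, 2 nitrogen; one six-membered non-aromatic ring with 1 hetero atom), on a carbonyl carbon with the rest of the structure shared. Going by the values given here, the only measured step, a 2.8-fold lower number from compound 1 to compound 2 (0.45 log units; beyond the scatter), has methyl in place of hydrogen on an amide-type nitrogen and bears on this change only in part, since more than that nitrogen differs here. On this thin basis, the expected move in this assay is a 4.1-fold higher number from compound 2 to compound 3 (0.61 log units; beyond the scatter), towards a higher number. Compound 3 is estimated at 0.45 10^-6 cm/s (expected range 0.12 10^-6 cm/s to 1.6 10^-6 cm/s).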

Compound 3, apparent permeability: 0.96 10^-6 cm/s
Compound 3: middle estimate off by 2.1-fold (0.33 log units), on the low side, and the stated range covers the measured number.
By their numbers in this assay, from the lowest: compound 2; then compound 1; then compound 3.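

In this assay, formyl in place of hydrogen on the amine nitrogen in a ring goes with a 3.1-fold higher number from compound 1 to compound 3 (0.49 log units; beyond the scatter) and is the first change shown to raise the number from compound 1. The step of an 8.7-fold higher number from compound 2 to compound 3 (0.94 log units; beyond the scatter) is larger, but it replaces the whole group on the carbonyl carbon, so it carries both the formyl and the loss of the methyl on the amide-type nitrogen.

Going by these compounds, whether acetyl or methyl on the same ring nitrogen would move the number as formyl does remains open. No measurement here explains either step.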